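The source may report more compounds than this note shows. Statements on the series, on what has been measured and on what is new or still open speak of the compounds shown alone.

Among the compounds with values here, compound 1 `NC(=O)CCCC/C=C(\c1ccccc1)c1cccnc1` gives 400 nM in an assay (Equus caballus) for inhibition of Thromboxane-A synthase (Homo sapiens), using microsomes (on this read-out lower numbers stand for stronger inhibition and higher numbers for weaker inhibition), the higher of the two numbers measured so far. Its nearest neighbour is compound 2 `CC(C)(CCC/C=C(\c1ccccc1)c1cccnc1)C(=O)O`, which gives 21 nM in this assay. The step of a 19-fold lower number from compound 1 to compound 2 (1.28 log units; beyond the scatter) comes from putting 1-carboxy-1-methylethyl in place of carbamoylmethyl on a saturated chain carbon, three bonds along the chain from a double-bonded chain carbon, so an amide end of the chain was exchanged for an acid end. Compound 3 `O=C(O)CCCCCCCCC/C=C(\c1ccccc1)c1cccnc1` has not yet been measured. Within the data shown here, it differs from compound 1 by 5-carboxypentyl in place of carbamoyl on a saturated chain carbon, four bonds along the chain from a double-bonded chain carbon; here too the amide end becomes an acid, but the chain is also made longer, and no measured pair shows what a longer chain does. Among the measured compounds shown here, the one measured step that bears on this change is the large gain from compound 1 to compound 2. For the measured compounds named here, a step of a 6.7-fold lower number from compound 1 to compound 3 (0.82 log units; beyond the scatter) toward a lower number is therefore expected, kept smaller than that measured step, as the longer chain has no counterpart among the measured compounds. Compound 3 is estimated at 60 nM, with a range from 12 nM to 300 nM.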

Compound 3, half-maximal inhibitory concentration: 55 nM
For compound 3 the middle estimate is 1.1-fold (0.04 log units) above the measured one; the measured number falls inside the stated range.
By their numbers in this assay, from the lowest: compound 2; then compound 3; then compound 1.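

In this assay, the carbamoyl group can give way to 5-carboxypentyl, which has 8 heavy atoms in place of 3, and the number still falls: a 7.3-fold lower number from compound 1 to compound 3 (0.86 log units; beyond the scatter). Compound 1 now has two measured neighbours with a carboxylic acid at the chain end, and both give lower numbers, so the gain is not confined to the 1-carboxy-1-methylethyl group of compound 2 and survives a much longer chain at this position. Nothing measured here explains why the acid-ended compounds give lower numbers than the amide.

The step from compound 1 to compound 3 changes the chain end and the chain length together, so the compounds shown cannot tell how much of it belongs to each change; an unbranched carboxylic acid with the chain length of compound 1, or an amide with the chain length of compound 3, would separate the two. Also open, going by these compounds, is how a different chain end, such as a methyl ester or an amine, or a chain of intermediate length would fare on the same core.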